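A few compounds are considered here, and "the series" means these few. Any claim that something is new, unique, unknown or untested is made for them only; others in the source may bear on it.

Compound 1 `COC(CC(C)C(O)/C=C/C=C/CNC(=O)C(C)(C)C(O)/C(C)=C\C=C/C=C/C(C)=C(\C)[N+](=O)[O-])C1(O)C(C)C(=O)N(C)C12C(=O)OC2C` gives > 100000 nM in a functional assay on SNU-638 cells (Homo sapiens) for cytotoxicity; a lower number here means a stronger inhibitor, a higher number a weaker inhibitor; this value is a limit of the assay, not a number.
Compound 2 `CO[C@@H](C[C@@H](C)[C@@H](O)/C=C/C=C/CNC(=O)C(C)(C)[C@H](O)/C(C)=C/C=C/C=C/C(C)=C(\C)[N+](=O)[O-])[C@]1(O)[C@@H](C)C(=O)N(C)[C@@]12COC2=O` gives > 100000 nM in this assay; this value too is a limit.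
Compound 3 `CO[C@@H](C[C@@H](C)[C@@H](O)/C=C/C=C/CNC(=O)C(C)(C)[C@H](O)/C(C)=C/C=C/C=C/C(C)=C(\C)[N+](=O)[O-])[C@]1(O)[C@@H](C)C(=O)N(C)[C@]12C(=O)O[C@@H]2C` gives > 100000 nM in this assay; this value is again a limit.

Compound 3 therefore stands at the limit, and so do the other two measured compounds, so none of the three can be placed above or below another. The two steps that lead into compound 3 are a step that the two limits leave unreadable from compound 1 to compound 3 and a step that the two limits leave unreadable from compound 2 to compound 3; both are hidden by the limits and give no readable size.

Compound 4 `CO[C@@H](C[C@@H](C)[C@@H](O)/C=C/C=C/CNC(=O)C(C)(C)[C@H](O)/C(C)=C\C=C\C=C\C(C)=C(/C)[N+](=O)[O-])[C@]1(O)[C@@H](C)C(=O)N(C)[C@]12C(=O)O[C@@H]2C` is the next compound. Its difference from compound 3 is the two compounds have the same atoms and bonds and differ only in configuration as drawn: 1 of 14 stereo elements differ; a double bond is drawn E in compound 3 and Z in compound 4. For the measured compounds named here, no measured step touches a change of this kind, so there is nothing to read a direction or size from. Going by the values given here, the only evidence is the limit of > 100000 nM in this assay, at which 3 of the 3 values shown sit, because of which every compound measured so far, whatever its drawn configuration, has stayed at the limit. The step of a number no higher from compound 3 to compound 4 (the limit leaves the size open) is expected to be none beyond the scatter, with compound 4 most likely remaining at the limit as well. Compound 4 is estimated at 100000 nM, in a range from 30000 nM to 300000 nM.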

Compound 4, half-maximal inhibitory concentration: > 100000 nM
Compound 4: a limit, no number (the forecaster's own chance of this, stated with the estimate: 85%); the middle value sits exactly at the limit.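

Compound 4 gives a limit of the assay, not a number, so the steps leading to it from compound 3 and from compound 1 cannot be read, because of this: the limit of > 100000 nM in this assay, at which 4 of the 4 values shown sit.

The compounds shown leave open how strongly any of them acts in this assay, and whether the double bond drawn E in compound 3 and Z in compound 4 changes that at all.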